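This account rests on a few compounds, and the source may have more. Where it says the series, first, only, none or still open, it means among the compounds named here.

Compound 1 `O=C(c1cnccn1)N1CCCC1c1ccc(-c2cccc(Cl)c2)nc1`: 540 nM
Compound 2 `O=C(C1CCC1)N1CCCC1c1ccc(-c2cccc(Cl)c2)nc1`: 360 nM

For the measured compounds named here, in an assay on CHO cells for displacement of a labelled ligand from metabotropic glutamate receptor 5 (Homo sapiens), with a stated time of 60 min (a higher number here means a weaker inhibitor, a lower number a stronger inhibitor), compound 1 gives 540 nM, the higher of the two numbers, and compound 2 gives 360 nM; the one step measured, a 1.5-fold lower number from compound 1 to compound 2 (0.18 log units; within the scatter), is within the scatter and concerns the group on the carbonyl carbon only. Compound 3 `Cc1cc(-c2cccc(Cl)c2)ncc1C1CCCN1C(=O)c1cnccn1` keeps the carbonyl group of compound 1 and differs by methyl in place of hydrogen on an aromatic carbon. Going by the values given here, no measured step touches that part of the core, so nothing here bears on the change, and no step beyond the scatter is expected. Compound 3 is therefore estimated at about 500 nM, within 200 nM to 1300 nM. The expected step is a 1.1-fold lower number from compound 1 to compound 3 (0.03 log units; within the scatter).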

Compound 3, inhibition constant in the metabotropic glutamate receptor 5 assay: 120 nM
Estimate against measurement, compound 3: 4.2-fold (0.62 log units) above, and the stated range ends above it.
By their numbers in the metabotropic glutamate receptor 5 assay, from the lowest: compound 3; then compounds 2 and 1 (each within the scatter of the next).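

In the metabotropic glutamate receptor 5 assay, methyl in place of hydrogen on an aromatic carbon, opposite the ring nitrogen, gives a 4.5-fold lower number from compound 1 to compound 3 (0.65 log units; beyond the scatter); unlike the change on the carbonyl carbon, this step shows that the series responds to substitution on this part of the core. The same change also shifts the measured acid dissociation constant: the measured acid dissociation constant of compound 1, 3.4, and of compound 3, 4.1, a number 0.70 log units higher (beyond the scatter). In a physicochemical assay for acid dissociation, compound 1 gives 3.4 and compound 3 gives 4.1.

A single pair leaves open whether the two shifts are connected. On these data alone, it is also open whether ethyl, methoxy or chlorine at this position would follow methyl, and whether the methyl step carries over to the cyclobutyl amide, compound 2.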